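A few compounds are considered here, and "the series" means these few. Any claim that something is new, unique, unknown or untested is made for them only; others in the source may bear on it.

In a physicochemical assay for solubility, in simulated intestinal fluid, measured as thermodynamic solubility, at pH 6.8 (a lower number here means a less soluble compound, a higher number a more soluble compound), two compounds have been measured so far. Compound 1 `CC(C)(C)OC(=O)N1CCCC(Nc2nc3c(c(Nc4ccc(C(F)(F)F)cc4)n2)CCN(c2ncccc2C(F)(F)F)CC3)C1` gives 14 ug/mL, while compound 2 `FC(F)(F)c1ccc(Nc2nc(N3CCN(C4CCC4)CC3)nc3c2CCN(c2ncccc2C(F)(F)F)CC3)cc1` gives 2 ug/mL. Compound 2 therefore holds the lower of the two numbers, and the gap between them lies beyond the scatter. Compound 3 `FC(F)(F)c1ccc(Nc2nc(NC3CCCNC3)nc3c2CCN(c2ncccc2C(F)(F)F)CC3)cc1` has not yet been measured. It departs from compound 2 in one place: (piperidin-3-yl)amino stands in place of 4-cyclobutylpiperazin-1-yl on an aromatic carbon, between two ring nitrogen atoms ((piperidin-3-yl)amino in place of 4-cyclobutylpiperazin-1-yl on an aromatic carbon). Going by the values given here, the two measured compounds do not form a pair differing in one place only, so no measured step speaks directly to this change. Among the compounds with values here, with only two readings to go on, a moderate rise beyond the scatter is expected, rather than a fall or no change, and the expectation remains uncertain. The expected step is a 5.0-fold higher number from compound 2 to compound 3 (0.70 log units; beyond the scatter). For compound 3 the estimated solubility is 10 ug/mL, with an expected range from 3 ug/mL to 40 ug/mL.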

Compound 3, solubility: 203 ug/mL
Estimate against measurement, compound 3: 20-fold (1.31 log units) below, outside the stated range (above it).
By their numbers in this assay, from the lowest: compound 2; then compound 1; then compound 3.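

In this assay, the aromatic carbon between two ring nitrogen atoms proves highly sensitive to its substituent: (piperidin-3-yl)amino in place of 4-cyclobutylpiperazin-1-yl gives a 100-fold higher number from compound 2 to compound 3 (2.01 log units; beyond the scatter) in a single change. The ring amine nitrogen of that group matters too, since hydrogen in place of tert-butoxycarbonyl gives a 15-fold higher number from compound 1 to compound 3 (1.16 log units; beyond the scatter) on the same substituent position, so both large steps end at compound 3, the only compound shown with hydrogen on that nitrogen. Nothing measured here gives a reason for either step.

The step from compound 2 to compound 3 changes the ring, the amino link and the cyclobutyl group together, so the compounds shown cannot separate their contributions in this assay. A piperazin-1-yl group carrying hydrogen in place of cyclobutyl would begin to separate them, while a methyl or acetyl group on the piperidine nitrogen would show how much of the step from compound 1 depends on that hydrogen.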